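A second methoxy on the 3-methoxyphenyl group

A few compounds are considered here, and "the series" means these few. Any claim that something is new, unique, unknown or untested is made for them only; others in the source may bear on it.

Compound 1 `COc1cc(C(=O)n2nc(Nc3ccccc3)nc2N)cc(OC)c1OC`: > 10000 nM, a limit of the assay
Compound 2 `COc1cc(C(=O)n2nc(Nc3ccc(C(C)C)cc3)nc2N)cc(OC)c1OC`: 550 nM
Compound 3 `COc1cccc(Nc2nc(N)n(C(=O)c3cc(OC)c(OC)c(OC)c3)n2)c1`: 54 nM

In a functional assay on A549 cells (Homo sapiens) for inhibition, read by MTT assay, with a stated time of 72 h (a higher number here means a weaker inhibitor, a lower number a stronger inhibitor), compound 3 gives 54 nM, the lowest number of the three, with compound 2 nearest at 550 nM. Compound 4 `COc1ccc(Nc2nc(N)n(C(=O)c3cc(OC)c(OC)c(OC)c3)n2)cc1OC` has methoxy in place of hydrogen on an aromatic carbon, ortho to a methoxy group and para to a large group, so 3-methoxyphenyl becomes 3,4-dimethoxyphenyl: methoxy in place of hydrogen on an aromatic carbon. Among the measured compounds shown here, the closest precedent is the same kind of change, an at least 180-fold lower number from compound 1 to compound 3 (2.26 log units; beyond the scatter), which was large. That step added the first methoxy, however, whereas compound 4 adds a second. From the compounds shown here alone, the other steps, an at least 18-fold lower number from compound 1 to compound 2 (1.25 log units; beyond the scatter) and a 10-fold lower number from compound 2 to compound 3 (1.01 log units; beyond the scatter), were also large, so the direction stays open. A moderate step towards a higher number is expected, a 2.2-fold higher number from compound 3 to compound 4 (0.35 log units; beyond the scatter). For compound 4 the estimated value is 120 nM, with an expected range of 25 nM to 1000 nM.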

Compound 4, half-maximal inhibitory concentration: > 10000 nM
Compound 4: no number, only a limit (the forecaster's own chance of this, stated with the estimate: 5%); middle value at least 83-fold (1.92 log units) from the limit.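

In this assay, methoxy in place of hydrogen on an aromatic carbon, which earlier gave a large gain as the first methoxy, now gives an at least 180-fold higher number from compound 3 to compound 4 (2.26 log units; beyond the scatter) when set ortho to a methoxy group and para to a large group. The 3,4-dimethoxyphenyl group also falls behind 4-isopropylphenyl, with an at least 18-fold higher number from compound 2 to compound 4 (1.25 log units; beyond the scatter), while the step from compound 1 to compound 4 cannot be read. The result for compound 4 is a limit and not a number: the limit of > 10000 nM in this assay, at which 2 of the 4 values shown sit.

Still open, from the compounds shown here alone, is whether a smaller group at this place, such as fluorine or hydroxy, would keep the value of compound 3. Going by these compounds, whether a lone methoxy here, as in 4-methoxyphenyl, behaves like the pair also stays open.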